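Chloro in place of hydrogen on the phenyl of compound 3

A few compounds are considered here, and "the series" means these few. Any claim that something is new, unique, unknown or untested is made for them only; others in the source may bear on it.

Three compounds on a shared core have been run in a functional assay on the whole organism for inhibition, with Mus musculus as the target, at a dose of 100 mg/kg by the oral route; a higher number here means more inhibition at the dose given (going by the name of the read-out), a lower number less inhibition. Compound 1 `Cc1ccc(C2=CCc3ccccc3N=C2N2CCN(C)CC2)cc1` gives 31%, compound 2 `Brc1ccc2c(c1)CC=C(c1ccccc1)C(N1CCNCC1)=N2` gives 31% and compound 3 `Clc1ccc2c(c1)N=C(N1CCNCC1)C(c1ccccc1)=CC2` gives 31%. In this assay compound 3 thus sits level with compounds 1 and 2, all within the scatter of one another. Compound 4 `Clc1ccc(C2=CCc3ccc(Cl)cc3N=C2N2CCNCC2)cc1` has not yet been run in this assay. From compound 3 it differs by chloro in place of hydrogen on an aromatic carbon, sitting on an aromatic carbon of a six-membered aromatic ring of carbon only, para to a large group; read one bond further out, phenyl to 4-chlorophenyl. Going by the values given here, no step between measured compounds covers this change, so its size is unknown. In this assay the step of no change at the digits printed from compound 3 to compound 4 (within the scatter) is expected to be none beyond the scatter. Compound 4 is therefore estimated at 31%, in a range from 18% to 45%.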

Compound 4, a percentage reported as inhibition, in the whole organism at one dose (the size of the read-out at that dose, not a potency): 31%
The estimate for compound 4 equals the measured number at the digits printed; low and high end bracket the measured number.
By their numbers in this assay, from the lowest: compounds 1, 2, 3 and 4 (each within the scatter of the next).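

In this assay, going by these compounds alone, the step of no change at the digits printed from compound 3 to compound 4 (within the scatter) is the first reading for this position: chloro in place of hydrogen, on an aromatic carbon para to a large group, leaves the single-dose read-out flat. Turning phenyl into 4-chlorophenyl therefore costs nothing measurable on the shared core at this dose. No measurement at hand accounts for this result.

From the compounds shown here alone, whether an amine, a carboxylic acid or a longer chain at this position would shift the read-out stays open. So does whether the same flatness would hold at other doses.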